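The source may hold more compounds than are shown below. What is called first, only, known or untested is meant among the compounds shown, and "the series" means these compounds.

Compound 1 `Nc1cc(C2CCNCc3cccc(c3)OCc3cccc(c3)Cn3cc2cn3)c2nn[nH]c2n1`: 8 nM
Compound 2 `Nc1cc(Cc2ccn(-c3ccc(F)cc3)n2)c2nn[nH]c2n1`: 53 nM
Compound 3 `Nc1cc(Cc2ccn(Cc3cccc(Cc4ccccc4)c3)n2)c2nn[nH]c2n1`: 39 nM

Of the compounds shown here, three sharing the same core have been tested in an assay on isolated protein for inhibition of Myeloperoxidase (Homo sapiens), with a stated time of 10 min; a lower number here means a stronger inhibitor, a higher number a weaker inhibitor. Compound 1 gives 8 nM, compound 2 gives 53 nM, and compound 3 gives 39 nM. Compound 3 stands second highest of the three numbers; its value and that of compound 2 lie within the scatter of each other, so no order can be read between them, while compound 1 has a number well beyond the scatter below both.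

Compound 4 `Nc1cc(Cc2ccn(Cc3cccc(C4CCNCC4)c3)n2)c2nn[nH]c2n1` has not yet been measured in this assay. It differs from compound 3 in one place: piperidin-4-yl in place of benzyl on an aromatic carbon. Among the compounds with values here, no pair of measured compounds shows exactly this exchange, so there is no measured step to lean on. Within the data shown here, the only guide is that compound 1, which also carries a ring bearing a nitrogen with one hydrogen, gives 8 nM in this assay, the lowest number so far. On that basis a small step toward a lower number is expected from compound 3 to compound 4, of size a 2.0-fold lower number from compound 3 to compound 4 (0.29 log units; within the scatter), though it could fall within the scatter. Compound 4 is therefore expected to give about 20 nM, with a range from 6 nM to 70 nM.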

Compound 4, half-maximal inhibitory concentration: 100 nM
Estimate against measurement, compound 4: 5.0-fold (0.70 log units) below; measured number outside the range, above it.
By their numbers in this assay, from the lowest: compound 1; then compounds 3, 2 and 4 (each within the scatter of the next, the first and the last beyond it).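

In this assay, within the data shown here, placing piperidin-4-yl instead of benzyl on this aromatic carbon gives a 2.6-fold higher number from compound 3 to compound 4 (0.41 log units; beyond the scatter) and this is the first measured step at this position. It shows that the group here does affect the number, and that a non-aromatic ring with one nitrogen does not improve on the benzyl group, despite the low number of compound 1, which differs from compound 4 in more than one place and so cannot serve as a guide to this single exchange. No measurement available here explains the rise.

As far as these compounds go, whether the rise follows the added nitrogen, the lost aromatic ring or the shorter link to the ring remains open; all three change in this single step. A cyclohexyl group in the same place would keep the non-aromatic ring without the nitrogen, and a phenyl group would keep the aromatic ring with the same direct link, so these two groups could begin to separate those changes.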